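Series notes: nitro for bromo at the para position

The source may hold more compounds than are shown below. What is called first, only, known or untested is meant among the compounds shown, and "the series" means these compounds.

The series shares one core. Compound 1 `Cc1ccccc1Nc1nnc(Nc2nc(-c3ccc(Cl)cc3)cs2)s1`, compound 2 `Cc1ccccc1Nc1nnc(Nc2nc(-c3ccc(Br)cc3)cs2)s1` and compound 3 `COc1ccc(Nc2nnc(Nc3nc(-c4ccc(Br)cc4)cs3)s2)cc1` have been measured in a functional assay on the whole organism (strain albino) with Mus musculus as the target, in the maximal electroshock model, with a stated time of 4 h; a lower number here means that less compound is needed, a higher number that more compound is needed for the effect. Compound 1 gives 300 mg/kg, compound 2 gives 300 mg/kg and compound 3 gives 100 mg/kg. Compound 2 stands level with compound 1 at the digits shown, the two together the highest of the three numbers; the other step is a 3.0-fold lower number from compound 2 to compound 3 (0.48 log units; beyond the scatter). Compound 4 `Cc1ccccc1Nc1nnc(Nc2nc(-c3ccc([N+](=O)[O-])cc3)cs2)s1` is not yet measured; it differs from compound 2 by nitro in place of bromo on an aromatic carbon, on an aromatic carbon para to a large group. Among the measured compounds shown here, the one step at that place, no change at the digits printed from compound 1 to compound 2 (within the scatter), bears directly on it; the step that lowers the number changes a different place. For compound 4 no step beyond the scatter is therefore expected, no change at the digits printed from compound 2 to compound 4 (within the scatter). Compound 4 is estimated at 300 mg/kg, within 150 mg/kg to 600 mg/kg.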

Compound 4, minimum effective dose: 100 mg/kg
For compound 4 the middle estimate is 3.0-fold (0.48 log units) above the measured one; measured number below the stated range.
By their numbers in this assay, from the lowest: compounds 3 and 4 (each within the scatter of the next); then compounds 1 and 2 (each within the scatter of the next).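

In this assay this position proves responsive to the group placed on it: the two halogens gave no readable difference, but nitro in place of bromo gives a 3.0-fold lower number from compound 2 to compound 4 (0.48 log units; beyond the scatter) and nitro in place of chloro gives a 3.0-fold lower number from compound 1 to compound 4 (0.48 log units; beyond the scatter) with the other groups on the core unchanged. The place held constant between compound 1 and compound 2 can thus move the dose on its own. No available data explain this step.

As far as these compounds go, whether an amine or a carboxylic acid at this position would follow nitro or the halogens remains open. Also open, from the compounds shown here alone, is whether the nitro step would persist with 4-methoxyphenyl in place of 2-methylphenyl.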